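Removing the tert-butoxycarbonyl group from compound 2

A few compounds are considered here, and "the series" means these few. Any claim that something is new, unique, unknown or untested is made for them only; others in the source may bear on it.

Compound 2 `CCCCCC(=O)c1ccc(OCCCN2CCN(C(=O)[C@@H](C)NC(=O)OC(C)(C)C)CC2)cc1` gives 10700 nM in an assay for binding affinity to histamine H2 receptor (Homo sapiens) (on this read-out lower numbers stand for stronger inhibition and higher numbers for weaker inhibition), the lowest of the three numbers in hand. Compound 1 `CC(C)(C)OC[C@@H](N)C(=O)N1CCN(CCCOc2ccc(C(=O)C3CC3)cc2)CC1` gives 45700 nM and compound 3 `CC(C)N[C@H](C)C(=O)N1CCN(CCCOc2ccc(C(=O)C3CC3)cc2)CC1` gives 50100 nM; both sit above compound 2 by more than the scatter. For the measured compounds named here, the only single-point step measured so far, a 1.1-fold higher number from compound 1 to compound 3 (0.04 log units; within the scatter), lies within the scatter and concerns the group on the amide carbonyl rather than a protecting group. Compound 4 `CCCCCC(=O)c1ccc(OCCCN2CCN(C(=O)[C@@H](C)N)CC2)cc1` differs from compound 2 by hydrogen in place of tert-butoxycarbonyl on an amine nitrogen. Going by the values given here, no measured step covers this change. Compounds 1 and 3 carry an amino group without a tert-butoxycarbonyl, as compound 4 would, but they also differ from compound 2 in the group on the ketone carbonyl, so their higher numbers cannot be read as the effect of the amine alone. The expectation is therefore weakly founded. A step of a 2.3-fold higher number from compound 2 to compound 4 (0.37 log units; beyond the scatter) is expected, upward. Compound 4 is estimated at 25000 nM, within a wide range from 6000 nM to 100000 nM.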

Compound 4, inhibition constant: 40700 nM
The estimate for compound 4 lay 1.6-fold (0.21 log units) below the measured number; the measured number falls inside the stated range.
By their numbers in this assay, from the lowest: compound 2; then compounds 4, 1 and 3 (each within the scatter of the next).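

In this assay, for the compounds shown here, the step of a 3.8-fold higher number from compound 2 to compound 4 (0.58 log units; beyond the scatter) gives the first reading of tert-butoxycarbonyl on this amine nitrogen with the group on the ketone carbonyl and the rest of the structure held constant. The earlier compounds shown here could not separate these two places, whereas this pair ties the difference to the change from (tert-butoxycarbonyl)amino to amino alone. This holds for one pair only, and no measurement here accounts for the step.

As far as these compounds go, whether an acetyl or a benzyloxycarbonyl group on this nitrogen would stay nearer compound 2 or compound 4 remains open. Also open is the contribution of the group on the ketone carbonyl, since no pair among the compounds shown differs there alone.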